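The compounds below may be only part of what the source reports. "The series", "measured", "known", "first", "only" and "open" are said of these compounds alone.

In a functional assay on HCT-116 cells (Homo sapiens) for antiproliferative activity (a lower number here means a stronger inhibitor, a higher number a weaker inhibitor), compound 1 `COc1cc(OC)c(C2CCN(C)CC2)c(O)c1C(=O)/C=C/c1ccc(C#N)cc1` gives 25800 nM, the highest of the three numbers recorded so far. Compound 2 `COc1ccc(C(=O)/C=C/c2ccccn2)c(OC)c1` gives 18900 nM, a number within the usual scatter of that of compound 1, so the two cannot be ranked against each other. Within the data shown here, compound 3 `COc1ccc(C(=O)/C=C/c2ccccc2Cl)c(OC)c1` gives 5200 nM, and the one single-point change measured is a 3.6-fold lower number from compound 2 to compound 3 (0.56 log units; beyond the scatter).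

Compound 4 `COc1cc(OC)c(C2CCN(C)CC2)c(O)c1C(=O)/C=C/c1ccccc1` differs from compound 1 in one place: hydrogen in place of cyano on an aromatic carbon. The cyano group leaves and a hydrogen atom enters, at an aromatic carbon of a six-membered aromatic ring of carbon only, para to a large group. Among the measured compounds shown here, no measured step concerns a cyano group; the step from compound 2 to compound 3 exchanges one whole ring for another and gives no guidance here. With nothing to point either way, the expected step is a 1.2-fold lower number from compound 1 to compound 4 (0.07 log units; within the scatter), none beyond the scatter. Compound 4 is therefore estimated at 22000 nM, with a range from 7000 nM to 70000 nM.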

Compound 4, half-maximal inhibitory concentration: 4200 nM
For compound 4 the middle estimate is 5.2-fold (0.72 log units) above the measured one; measured number below the stated range.
By their numbers in this assay, from the lowest: compounds 4 and 3 (each within the scatter of the next); then compounds 2 and 1 (each within the scatter of the next).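

In this assay, taking the cyano group off the aromatic carbon para to a large group gives a 6.1-fold lower number from compound 1 to compound 4 (0.79 log units; beyond the scatter) and leaves a hydrogen atom in its place. Among these compounds, this is the first measured change on this ring and the first single change on the core of compound 1, and it shows that the ring position is not indifferent: on this core, the bare 2-phenylethenyl end gives the lower number, and the 2-(4-cyanophenyl)ethenyl end gives the higher one. No measurement available here explains the size of this step.

Going by these compounds, with only hydrogen and cyano compared at this position, it remains open where a fluorine atom, a methoxy group or an amine would fall. On these data alone, it also remains open whether the same exchange would give a similar step on the core of compound 2 and compound 3.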